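Second methoxy group on compound 1: working notes

The compounds below may be only part of what the source reports. "The series", "measured", "known", "first", "only" and "open" are said of these compounds alone.

Measured so far:
compound 1 `COc1ccc(-c2cc(/C=C/C(=O)c3ccc(N)cc3)[nH]n2)cc1` — 89%
compound 2 `COc1ccc(C(=O)/C=C/c2cc(-c3cc(OC)c(OC)c(OC)c3)n[nH]2)cc1` — 96%

In a functional assay on NCI-H322M cells (Homo sapiens) for cytotoxicity, read by sulforhodamine B assay, with a stated time of 48 h, tested at 0.1 uM (a lower number here means a stronger effect, a higher number a weaker effect of the compound at the concentration tested), compound 1 gives 89%, the lower of the two numbers in hand. Compound 2 gives 96% in this assay, which lies within the scatter of the number for compound 1, so the two cannot be ordered. Both numbers sit near the top of the scale, so the effect at this concentration is weak for both.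

Compound 3 `COc1ccc(-c2cc(/C=C/C(=O)c3ccc(N)cc3)[nH]n2)cc1OC` differs from compound 1 by methoxy in place of hydrogen on an aromatic carbon.

Within the data shown here, no pair of measured compounds differing in one place is available, so the size of this step has no direct precedent. Given that compound 1 and compound 2 already sit close to the top of the scale in this assay, the step of a number 1 percentage points higher from compound 1 to compound 3 (within the scatter) is expected to stay within the scatter, with no clear direction. Compound 3 is therefore estimated to give 90% in this assay, in a range from 76% to 102%.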

Compound 3, a percentage reported as activity, at one concentration (the size of the read-out at that concentration, not a potency): 102%
Compound 3: the middle estimate sits 12 percentage points below what was measured; measured number inside the range.
By their numbers in this assay, from the lowest: compounds 1, 2 and 3 (each within the scatter of the next, the first and the last beyond it).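

In this assay, among these compounds, methoxy in place of hydrogen on an aromatic carbon, ortho to a methoxy group and meta to a large group, gives a number 13 percentage points higher from compound 1 to compound 3 (beyond the scatter), the first step that can be read at a single place. The direction is toward a weaker effect at the concentration tested, so this position does not gain from the added methoxy, although the evidence is one modest step from one pair. Nothing at hand bears on the reason for this step.

From the compounds shown here alone, whether a hydroxy group, an ethoxy group or an amine at the same position would move the number the same way remains open. A read-out at one concentration also leaves open whether the step reflects any difference in potency.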